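A few compounds are considered here, and "the series" means these few. Any claim that something is new, unique, unknown or untested is made for them only; others in the source may bear on it.

Two compounds have been measured so far:
compound 1, `O=C(O)CC/C=C\CC1COC(c2cccc3ccccc23)OC1c1cccnc1`, 40 nM
compound 2, `CC(C)(Oc1ccccc1F)C1OCC(C/C=C\CCC(=O)O)C(c2cccnc2)O1`, 45 nM

Both numbers come from an assay for inhibition of Thromboxane-A synthase (Homo sapiens), using microsomes; on this read-out higher numbers stand for weaker inhibition and lower numbers for stronger inhibition. On this read-out compound 2 has the higher of the two numbers, but its nearest neighbour, compound 1, sits within the usual scatter of it, so the two cannot be told apart on the evidence at hand. Among the measured compounds shown here, no pair of measured compounds differs in only a single place, so there is no measured step of any kind to lean on.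

Compound 3, `CC(C)(C1OCC(C/C=C\CCC(=O)O)C(c2cccnc2)O1)S(=O)(=O)c1ccccc1`, has not yet been measured in this assay. It differs from compound 2 in one place: phenylsulfonyl in place of 2-fluorophenoxy on a saturated chain carbon bound to two saturated chain carbons and a saturated ring carbon. The group that leaves and the group that enters are each built around one six-membered aromatic ring of carbon only, and everything else in compound 2 is kept.

For the measured compounds named here, with no measured step to guide it, the change from compound 2 to compound 3 is expected to be modest, a 1.6-fold higher number from compound 2 to compound 3 (0.19 log units; within the scatter), close to the edge of the scatter and leaning toward a higher number. Compound 3 is therefore estimated at 70 nM, with a range from 20 nM to 250 nM.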

Compound 3, half-maximal inhibitory concentration: 40 nM
Compound 3: the middle estimate sits 1.8-fold (0.24 log units) above what was measured; measured number inside the range.
By their numbers in this assay, from the lowest: compounds 1, 3 and 2 (each within the scatter of the next).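

In this assay, among the compounds shown here, putting phenylsulfonyl in place of 2-fluorophenoxy on a saturated chain carbon bound to two saturated chain carbons and a saturated ring carbon gives a 1.1-fold lower number from compound 2 to compound 3 (0.05 log units; within the scatter) and is the first measured step in this set, so the two groups cannot be told apart on this read-out. At this position, then, the number holds within the scatter even though the entering group brings sulfur, 2 double bonds outside aromatic rings and 2 hydrogen-bond acceptors against 1, while the fluorine goes, and both groups keep one six-membered aromatic ring of carbon only. Nothing measured here explains why the number holds.

One swap between two groups that both carry such a ring cannot show whether the ring itself matters at this place, which a simple amine or a plain methyl there would test. Nor can it show how far the group may grow or change, as a sulfonamide or a cyclohexyl group in the same place might reveal.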